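The source may hold more compounds than are shown below. What is called first, only, known or untested is meant among the compounds shown, and "the series" means these compounds.

Measured so far: compound 1 `C[Si](C)(C)Cn1nnc2c(C(N)=O)ncn2c1=O` at 28400 nM; compound 2 `COc1ccc(Cn2nnc3c(C(N)=O)ncn3c2=O)c(OC)c1` at > 50000 nM.

Going by the values given here, in a functional assay on SNB-19 cells (Homo sapiens) for inhibition, read by MTT assay, with a stated time of 7 days (a lower number here means a stronger inhibitor of growth, a higher number a weaker inhibitor of growth), compound 1 gives 28400 nM, the only number among the two values. Compound 2 returns only a limit of the assay, > 50000 nM, as noted by the limit of > 50000 nM in this assay, at which 1 of the 2 values shown sits. Compound 3 `Cc1cc(Cn2nnc3c(C(N)=O)ncn3c2=O)on1` differs from compound 1 by a group of 6 heavy atoms (4 carbon, 1 nitrogen, 1 oxygen; one five-membered aromatic ring with 2 hetero atoms) in place of a group of 4 heavy atoms (3 carbon, 1 silicon; no ring), on a saturated chain carbon bound to an aromatic nitrogen. Among the compounds with values here, no measured step covers such a change; compound 2 also carries a ring and reached only a limit, so a step toward weaker growth inhibition in this assay, likely beyond the scatter, is expected. Compound 3 is thus estimated at 45000 nM, between 15000 nM and 150000 nM, a step of a 1.6-fold higher number from compound 1 to compound 3 (0.20 log units; within the scatter).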

Compound 3, concentration for 50% growth inhibition: > 50000 nM
Compound 3 ended at the assay's limit; the forecaster's own chance of this, stated with the estimate: 45%; at least 1.1-fold (0.04 log units) between middle value and limit.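

In this assay, putting 3-methyl-1,2-oxazol-5-yl in place of the silicon-bearing group, on a saturated chain carbon bound to an aromatic nitrogen, gives an at least 1.7-fold higher number from compound 1 to compound 3 (0.24 log units; that floor lies within the scatter). Compound 3 reaches only a limit, > 50000 nM, so this step is a floor and does not establish a change beyond the scatter. The silicon-bearing group of compound 1 remains the only group shown here that gives a number rather than a limit: the limit of > 50000 nM in this assay, at which 2 of the 3 values shown sit.

Left open is how a longer alkyl chain or a carboxylic acid at this place would compare with compound 1 at 28400 nM.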